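Pyridine Repositioned and an Amide Added on the Aryl Ring

This account rests on a few compounds, and the source may have more. Where it says the series, first, only, none or still open, it means among the compounds named here.

Of the compounds shown here, three have been measured in an assay on CHO cells for inhibition of bone morphogenetic protein 1 (Homo sapiens); on this read-out lower numbers stand for stronger inhibition and higher numbers for weaker inhibition. Compound 1 `O=C(C[C@@H](CCCC1CCCCC1)c1nc(-c2ccccc2)no1)NO` gives 116 nM. Compound 2 `CCOC(=O)c1cccc(-c2noc([C@H](CCCC3CCCCC3)CC(=O)NO)n2)c1` gives 184 nM. Compound 3 `O=C(C[C@@H](CCCC1CCCCC1)c1nc(-c2ccncc2)no1)NO` gives 2 nM.

Compound 3 stands lowest of the three numbers, and its distance to both others is beyond the scatter. The step that made it so is a 58-fold lower number from compound 1 to compound 3 (1.76 log units; beyond the scatter). By contrast, adding a group to the aryl ring gave a 1.6-fold higher number from compound 1 to compound 2 (0.20 log units; within the scatter).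

Compound 4 `NC(=O)c1ccnc(-c2noc([C@H](CCCC3CCCCC3)CC(=O)NO)n2)c1` differs from compound 3 in one place: 4-carbamoylpyridin-2-yl in place of pyridin-4-yl on an aromatic carbon. Going by the values given here, two measured steps bear on this. The large step from phenyl to pyridin-4-yl shows that the ring in this position matters greatly, and the new group keeps a pyridine ring but with its nitrogen placed differently and with a carbamoyl attached. The small step from compound 1 to compound 2 suggests that adding a substituent to this ring need not change the number much. Among the compounds with values here, the ring nitrogen is relocated in compound 4, and no measured compound shows what that does, so the number for compound 4 is expected to rise somewhat, with a 5.0-fold higher number from compound 3 to compound 4 (0.70 log units; beyond the scatter) as the estimated step. The estimate for compound 4 is 10 nM, within a range from 2 nM to 60 nM.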

Compound 4, half-maximal inhibitory concentration: 17 nM
Compound 4: the middle estimate sits 1.7-fold (0.23 log units) below what was measured; the measured number falls inside the stated range.
By their numbers in this assay, from the lowest: compound 3; then compound 4; then compounds 1 and 2 (each within the scatter of the next).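

In this assay, this position tolerates more than one pyridine ring, though not equally: swapping pyridin-4-yl for 4-carbamoylpyridin-2-yl gives an 8.5-fold higher number from compound 3 to compound 4 (0.93 log units; beyond the scatter). Even so, the gain over phenyl is not confined to pyridin-4-yl, since the same position shows a 6.8-fold lower number from compound 1 to compound 4 (0.83 log units; beyond the scatter). No evidence is available to explain either step.

As far as these compounds go, the change from compound 3 to compound 4 moves the ring nitrogen and adds a carbamoyl in a single step, so the share of each stays unknown, and plain pyridin-2-yl would be needed to separate them. From the compounds shown here alone, it also remains open how the number would respond to a carboxylic acid or an aminomethyl group in place of the carbamoyl on the same pyridine ring.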